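A few compounds are considered here, and "the series" means these few. Any claim that something is new, unique, unknown or untested is made for them only; others in the source may bear on it.

Compound 1 `COc1ccc(C(=O)/C=C/c2cc3ccccc3[nH]c2=O)cc1` gives 2490 nM in a functional assay on OVCAR-3 cells (Homo sapiens) for cytotoxicity, read by sulforhodamine B assay, with a stated time of 24 h; a lower number here means a stronger inhibitor of growth, a higher number a weaker inhibitor of growth. Compound 2 `O=C(/C=C/c1cc2ccccc2[nH]c1=O)c1ccc(O)cc1` gives 3220 nM in this assay. The step of a 1.3-fold higher number from compound 1 to compound 2 (0.11 log units; within the scatter) leaves compound 2 alongside compound 1, the two within the scatter of each other. Compound 3 `O=C(/C=C/c1cc2ccccc2[nH]c1=O)c1ccc(Cl)cc1` carries chloro in place of hydroxy on an aromatic carbon, para to a large group. Among the compounds with values here, no measured step exchanges hydroxy for chloro on this ring; the only known change at this position, a hydrogen in place of methyl on an oxygen, stayed within the scatter, so no step beyond the scatter is expected in this assay. The expected step is a 1.2-fold lower number from compound 2 to compound 3 (0.09 log units; within the scatter). Compound 3 is therefore estimated at 2600 nM, within 1000 nM to 7000 nM.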

Compound 3, concentration for 50% growth inhibition: 5900 nM
Compound 3: the middle estimate sits 2.3-fold (0.36 log units) below what was measured; low and high end bracket the measured number.
By their numbers in this assay, from the lowest: compounds 1, 2 and 3 (each within the scatter of the next, the first and the last beyond it).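

In this assay, within the data shown here, putting chloro in place of hydroxy on this aromatic carbon gives a 1.8-fold higher number from compound 2 to compound 3 (0.26 log units; within the scatter), while chloro in place of methoxy gives a 2.4-fold higher number from compound 1 to compound 3 (0.37 log units; beyond the scatter) and is the first modest step beyond the scatter at this position. Compound 3 thus separates from compound 1 but not from compound 2. Nothing available accounts for this result. From the compounds shown here alone, how an amine, a carboxylic acid or a longer chain such as ethoxy would read at this position stays open.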